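A Sulfonamide End in Place of the Carbamate Chain

This account rests on a few compounds, and the source may have more. Where it says the series, first, only, none or still open, it means among the compounds named here.

Compound 3 `CC(C)(C)OC(=O)NCCCCCNC(=O)CN1CN(c2ccccc2)C2(CCN(C(=O)c3ccc(C(C)(C)C)cc3)CC2)C1=O` gives 13700 nM in an assay on HEK293 cells for displacement of a labelled ligand from NPC1-like intracellular cholesterol transporter 1 (Homo sapiens) (a lower number here means a stronger inhibitor, a higher number a weaker inhibitor), the highest number of the three, although compound 1 `CC(C)(C)OC(=O)NCCNC(=O)CN1CN(c2ccccc2)C2(CCN(C(=O)c3ccc(C(C)(C)C)cc3)CC2)C1=O` gives 10900 nM and that gap is within the scatter; compound 2 `CC(C)(C)c1ccc(C(=O)N2CCC3(CC2)C(=O)N(CC(=O)NCCO)CN3c2ccccc2)cc1` gives 1000 nM. Compound 4 `CC(C)(C)c1ccc(C(=O)N2CCC3(CC2)C(=O)N(CC(=O)NCNS(C)(=O)=O)CN3c2ccccc2)cc1` differs from compound 3 by methanesulfonamido in place of 4-((tert-butoxycarbonyl)amino)butyl on a saturated chain carbon bound to an amide-type nitrogen. Among the measured compounds shown here, the steps that bear on this are a 14-fold higher number from compound 2 to compound 3 (1.14 log units; beyond the scatter) and an 11-fold lower number from compound 1 to compound 2 (1.04 log units; beyond the scatter), each showing a large drop when a hydroxy end stands in place of the carbamate chain, whereas a 1.3-fold higher number from compound 1 to compound 3 (0.10 log units; within the scatter) shows that lengthening that chain changes little. A short sulfonamide end is therefore expected to behave more like the hydroxy end, giving a step of a 6.9-fold lower number from compound 3 to compound 4 (0.84 log units; beyond the scatter). Compound 4 is estimated at 2000 nM, in a range from 600 nM to 7000 nM.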

Compound 4, half-maximal inhibitory concentration: 3200 nM
Beside the measured number, compound 4's estimate is 1.6-fold (0.20 log units) below it; low and high end bracket the measured number.
By their numbers in this assay, from the lowest: compound 2; then compound 4; then compounds 1 and 3 (each within the scatter of the next).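

In this assay the methanesulfonamido end gives a 4.3-fold lower number from compound 3 to compound 4 (0.63 log units; beyond the scatter) and a 3.4-fold lower number from compound 1 to compound 4 (0.53 log units; beyond the scatter) so the carbamate chains can be improved on by an end other than hydroxy. That end does not match hydroxy, however, since the change gives a 3.2-fold higher number from compound 2 to compound 4 (0.51 log units; beyond the scatter) and so separates two ends that each improve on the carbamate chains. As far as these compounds go, whether an amine or a carboxylic acid at this place would come closer to compound 2 remains open, as does the effect of a longer chain ending in methanesulfonamido. Nothing available accounts for the order of these ends.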